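The compounds below may be only part of what the source reports. "The series", "measured", "known", "first", "only" and "open" are said of these compounds alone.

Of the compounds shown here, two have been measured so far in a physicochemical assay for acid dissociation. Compound 1 `C#CC1CCCCC1OC[n+]1ccn(C)c1/C=N/O` gives 8.03 and compound 2 `C#CCCOC[n+]1ccc(/C=N/O)cc1` gives 8.18, so these two numbers lie within the usual scatter of each other. Compound 3 `C#CCCCC[n+]1ccc(/C=N/O)cc1` has not yet been measured. It differs from compound 2 in one place, with pent-4-yn-1-yl in place of (but-3-yn-1-yl)oxy on a saturated chain carbon bound to an aromatic nitrogen. Going by the values given here, no measured pair shows what this exchange does in this assay, so the expectation is a judgement from the structural change alone. The expected direction is upward, meaning that the proton would be given up less readily. The estimated a number 0.27 log units higher from compound 2 to compound 3 (within the scatter) is small, close to the edge of the scatter. For compound 3 the expected value is 8.45, with an estimated range from 8.2 to 8.7.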

Compound 3, acid dissociation constant: 8.36
Beside the measured number, compound 3's estimate is 0.09 log units above it; the measured number falls inside the stated range.
By their numbers in this assay, from the lowest: compounds 1, 2 and 3 (each within the scatter of the next, the first and the last beyond it).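

In this assay, going by these compounds alone, the exchange of (but-3-yn-1-yl)oxy for pent-4-yn-1-yl gives the first step that can be read at this position: a number 0.18 log units higher from compound 2 to compound 3 (within the scatter) on a saturated chain carbon bound to an aromatic nitrogen. The leaving chain holds one oxygen and the entering chain holds only carbon, with the same count of heavy atoms, and this exchange leaves the two numbers within the ordinary spread of repeated measurements. A single pair therefore shows no effect of the exchange that can be told apart from that spread, and nothing available bears on the reason for the step.

Still open, going by these compounds, is whether an amine, a carboxylic acid or a longer chain at this place would move the number beyond the scatter. Also open, on these data alone, is whether the same exchange would give a similar step on the core of compound 1.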